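The source may report more compounds than this note shows. Statements on the series, on what has been measured and on what is new or still open speak of the compounds shown alone.

Working notes on the series. Compound 1 `COc1cc(C)cc(-c2c(-c3ccnc(-c4ccc(C(C)=O)cc4)c3)cnn2CC#N)c1` is the reference point here. In a functional assay on BT-549 cells (Homo sapiens) for cytotoxicity, read by sulforhodamine B assay, with a stated time of 48 h, tested at 1 uM (on this read-out lower numbers stand for a stronger effect and higher numbers for a weaker effect at the one concentration tested), compound 1 gives 17%, which is the highest of the three numbers at hand. Compound 2 `Cc1cc(O)cc(-c2nn(CC#N)cc2-c2ccnc(-c3ccc(Oc4ccccc4)cc3)c2)c1` gives 4% in this assay, a number lower than that of compound 1 by a gap beyond the scatter. Compound 3 `COc1cc(C)cc(-c2nn(CC#N)cc2-c2ccnc(-c3ccc(N(C)C)cc3)c2)c1` gives -10% in this assay, the lowest of the three and further from compound 1 than compound 2 is, again beyond the scatter. No two of the measured compounds differ in one place only, so no single step can be read off among them.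

Compound 4 `COc1cc(C)cc(-c2c(-c3ccnc(-c4ccc(N(C)C)cc4)c3)cnn2CC#N)c1` has not been measured. It differs from compound 1 in one place: dimethylamino in place of acetyl on an aromatic carbon. Compound 3 also carries a dimethylamino group and gives the lowest number of the set, but it is not a single-change neighbour of compound 1, so only the two values can be compared, not the change itself. Taking this as the only guide, the change from compound 1 to compound 4 is expected to lower the number beyond the scatter, the expected step being a number 17 percentage points lower from compound 1 to compound 4 (beyond the scatter). For compound 4 in this assay the estimate is 0%, with a range from -18% to 18%.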

Compound 4, a percentage reported as activity, at one concentration (the size of the read-out at that concentration, not a potency): -29%
For compound 4 the middle estimate is 29 percentage points above the measured one; the whole stated range lies above it.
By their numbers in this assay, from the lowest: compound 4; then compound 3; then compound 2; then compound 1.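

Within the data shown here, the swap of acetyl for dimethylamino, on an aromatic carbon para to a large group, gives the first single-change step: in this assay, it produces a number 46 percentage points lower from compound 1 to compound 4 (beyond the scatter), so this position on the shared core clearly responds to the group it carries. Acetyl and dimethylamino have the same counts of heavy atoms and hydrogen-bond acceptors, neither has a hydrogen-bond donor or a net charge, and the step therefore comes without any change in those counts, with a carbonyl oxygen giving way to a nitrogen bearing two methyl groups. No measurement at hand accounts for the size of this step.

As far as these compounds go, the two compounds cannot separate the loss of acetyl from the gain of dimethylamino, so what a primary amine, a methoxy group or a carboxylic acid would give at this carbon remains open. Also open, from the compounds shown here alone, is whether the same swap gives a step of similar size at other concentrations, in other cell lines, or on the arrangement of the core seen in compound 3.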